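Chlorophenyl in place of trifluoromethylphenyl on the shared core

This account rests on a few compounds, and the source may have more. Where it says the series, first, only, none or still open, it means among the compounds named here.

Of the compounds shown here, three have been tested in a functional assay on ECa-109 cells (Homo sapiens) for inhibition, read by MTT assay, with a stated time of 72 h; a lower number here means a stronger inhibitor, a higher number a weaker inhibitor. Compound 1 `C#CCSc1nc(Nc2ccc(OC)cc2)c(C#N)c(-c2ccccc2)n1` gives 23200 nM there. Compound 2 `C#CCSc1nc(Nc2cccc(C(F)(F)F)c2)c(C#N)c(-c2ccccc2)n1` gives only a limit of this assay, > 128000 nM. Compound 3 `N#Cc1c(Nc2cccc(C(F)(F)F)c2)nc(SCc2cn(Cc3ccccc3Cl)nn2)nc1-c1ccccc1` gives 32000 nM in this assay, a number that lies within the usual scatter of the number for compound 1, so the two cannot be told apart. Where compound 3 stands relative to compound 2 remains open, since the limit of > 128000 nM in this assay, at which 1 of the 3 values shown sits, sets no number.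

Compound 4 `N#Cc1c(Nc2ccc(Cl)cc2)nc(SCc2cn(Cc3ccccc3Cl)nn2)nc1-c1ccccc1` differs from compound 3 by 4-chlorophenyl in place of 3-(trifluoromethyl)phenyl on a nitrogen on an aromatic ring. Within the data shown here, no measured step mirrors this change. The step from compound 3 to compound 4 is expected to be modest, a 1.6-fold lower number from compound 3 to compound 4 (0.20 log units; within the scatter), towards a lower number but not clearly beyond the scatter. Compound 4 is therefore estimated at 20000 nM, likely between 7000 nM and 60000 nM.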

Compound 4, half-maximal inhibitory concentration: 1420 nM
For compound 4 the middle estimate is 14-fold (1.15 log units) above the measured one, and the stated range ends above it.
By their numbers in this assay, from the lowest: compound 4; then compounds 1 and 3 (each within the scatter of the next). At a limit, above all of these: compound 2.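

With 4-chlorophenyl in place of 3-(trifluoromethyl)phenyl on the nitrogen, this assay shows a 23-fold lower number from compound 3 to compound 4 (1.35 log units; beyond the scatter), so this position is far from indifferent to the group it carries. Among these compounds, the earlier compounds gave no readable step here, since the only other pair differing at this place rests on a limit. Nothing shown speaks to the cause of this step.

The change alters both the group and its place on the phenyl ring, so the two remain unseparated. From the compounds shown here alone, how 3-chlorophenyl, 4-(trifluoromethyl)phenyl or an aminophenyl would read stays open.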